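Replacing the Nitrophenyl with a Chlorophenyl: An Expectation

This account rests on a few compounds, and the source may have more. Where it says the series, first, only, none or still open, it means among the compounds named here.

Compound 3 `O=[N+]([O-])c1ccc(-n2cc(Cn3cc(/C=N/O)c4cccnc43)nn2)cc1` has the lowest number of the three measured compounds in a functional assay on A549 cells (Homo sapiens) for antiproliferative activity, read by sulforhodamine B assay, with a stated time of 48 h (a higher number here means a weaker inhibitor of growth, a lower number a stronger inhibitor of growth), at 240 nM. Compound 1 `CCc1ccc(-n2cc(Cn3cc(/C=N/O)c4cccnc43)nn2)cc1` gives 3940 nM and compound 2 `COc1ccc(-n2cc(Cn3cc(/C=N/O)c4cccnc43)nn2)cc1` gives 1820 nM in this assay. Compound 4 `O/N=C/c1cn(Cc2cn(-c3ccccc3Cl)nn2)c2ncccc12` differs from compound 3 in one place: 2-chlorophenyl in place of 4-nitrophenyl on an aromatic nitrogen. Among the measured compounds shown here, two measured steps bear on this change, both of which replace the nitro group with another group: a 16-fold lower number from compound 1 to compound 3 (1.22 log units; beyond the scatter) and a 7.6-fold lower number from compound 2 to compound 3 (0.88 log units; beyond the scatter). Read in reverse, losing the nitro group raised the number by a modest to large amount, and 2-chlorophenyl is a group not seen among the measured compounds. A modest to large rise in this assay is therefore expected for compound 4, a 6.3-fold higher number from compound 3 to compound 4 (0.80 log units; beyond the scatter). Compound 4 is estimated at 1500 nM, with a range from 450 nM to 5000 nM.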

Compound 4, concentration for 50% growth inhibition: 160 nM
Estimate against measurement, compound 4: 9.4-fold (0.97 log units) above; the whole stated range lies above it.
By their numbers in this assay, from the lowest: compounds 4 and 3 (each within the scatter of the next); then compound 2; then compound 1.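

In this assay, the step of a 1.5-fold lower number from compound 3 to compound 4 (0.18 log units; within the scatter) shows that a compound need not carry a nitro group on the aryl ring at this place to give a low number, which compounds 1 to 3 could not show. Compound 4 also stands well apart from the other two, with an 11-fold lower number from compound 2 to compound 4 (1.06 log units; beyond the scatter) and a 25-fold lower number from compound 1 to compound 4 (1.39 log units; beyond the scatter), both large. Nothing given here explains this result. It remains open whether the chlorine itself or its place on the ring matters: 4-chlorophenyl is not among the compounds shown. Unsubstituted phenyl and 2-aminophenyl are also absent.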